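Swapping the Ring on a Piperazine Nitrogen

A few compounds are considered here, and "the series" means these few. Any claim that something is new, unique, unknown or untested is made for them only; others in the source may bear on it.

Compound 3 `Nc1ccccc1NC(=O)c1ccc(CSC(=S)N2CCN(c3ccncc3)CC2)cc1` stands highest of the three compounds measured in a functional assay on HeLa cells (Homo sapiens) for antiproliferative activity, read by CCK-8 assay, with a stated time of 72 h, tested at 2 uM; on this read-out higher numbers stand for a stronger effect at the one concentration tested and lower numbers for a weaker effect. In this assay compound 3 gives 77%. Compound 1 `Nc1ccccc1NC(=O)c1ccc(CSC(=S)N2CCc3cc([N+](=O)[O-])ccc32)cc1` gives 32.6% in this assay, and compound 2 `Nc1ccccc1NC(=O)c1ccc(CSC(=S)N2CCCc3ccccc32)cc1` gives 26.1%; each of these lies beyond the scatter below compound 3. Compound 4 `Cc1ccc(N2CCN(C(=S)SCc3ccc(C(=O)Nc4ccccc4N)cc3)CC2)cc1` has not yet been measured. It differs from compound 3 in one place: 4-methylphenyl in place of pyridin-4-yl on an amine nitrogen in a ring. Among the compounds with values here, no measured pair separated by only this change exists. The amine ring itself differs between compound 3 and compounds 1 and 2, so those numbers say little about changing only the group on that nitrogen. A modest downward step, estimated at a number 17 percentage points lower from compound 3 to compound 4 (beyond the scatter), is expected, possibly within the scatter. Compound 4 is expected to give 60% in this assay, within a range from 30% to 85%.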

Compound 4, a percentage reported as inhibition, at one concentration (the size of the read-out at that concentration, not a potency): 25.3%
Compound 4: the middle estimate sits 34.7 percentage points above what was measured; the whole stated range lies above it.
By their numbers in this assay, from the lowest: compounds 4, 2 and 1 (each within the scatter of the next); then compound 3.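

Exchanging pyridin-4-yl for 4-methylphenyl on the amine nitrogen in the ring gives, in this assay, a number 51.7 percentage points lower from compound 3 to compound 4 (beyond the scatter) and so a large loss of effect. This first pair differing in that one place shows that the group held there can strongly change the read-out. No measurement shown here explains the drop. The step both removes the ring nitrogen of pyridin-4-yl and adds a methyl, and the compounds shown cannot separate these two changes. Plain phenyl or pyridin-3-yl at this place would be needed to tell them apart.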